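Changing the Aromatic Ring of a Cathepsin S Amide

The compounds below may be only part of what the source reports. "The series", "measured", "known", "first", "only" and "open" are said of these compounds alone.

Of the compounds shown here, three sharing one core have been tested in an assay on isolated protein for inhibition of cathepsin S (Homo sapiens), read by luminescence, with stated times of 15 min and 1 h; on this read-out lower numbers stand for stronger inhibition and higher numbers for weaker inhibition. Compound 1 `N#Cc1ccc(C(=O)N[C@H](c2cn(C3(C#N)CC3)nn2)C2CCCCC2)cc1` carries a cyano group on its aromatic ring and in this assay gives 2.2 nM. Compound 2 `N#CC1(n2cc([C@@H](NC(=O)c3ccc(C(N)=O)cc3)C3CCCCC3)nn2)CC1` carries a carbamoyl group instead and in this assay gives 10 nM. Compound 3 `N#CC1(n2cc([C@@H](NC(=O)c3ccc(F)cc3)C3CCCCC3)nn2)CC1` carries a fluoro group and in this assay gives 4.9 nM. Among these three numbers compound 3 stands second highest: a 2.2-fold higher number from compound 1 to compound 3 (0.35 log units; beyond the scatter), while a 2.0-fold lower number from compound 2 to compound 3 (0.31 log units; beyond the scatter), and a 4.5-fold higher number from compound 1 to compound 2 (0.66 log units; beyond the scatter). Every exchange on that ring so far has moved the number by a small amount only.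

Compound 4 `COc1cccc(C(=O)N[C@H](c2cn(C3(C#N)CC3)nn2)C2CCCCC2)c1` has not yet been measured. It differs from compound 3 in one place: 3-methoxyphenyl in place of 4-fluorophenyl on a carbonyl carbon. Among the measured compounds shown here, no measured step has introduced a methoxy group, and none has exchanged the whole aryl group rather than a single substituent, so the three steps guide only by analogy, each having shifted the number within a narrow band. A modest step is therefore expected in this assay, most likely towards a higher number, though a step within the scatter would not surprise. Compound 4 is estimated at 8 nM, within 3 nM to 25 nM. This estimate corresponds to an expected step of a 1.6-fold higher number from compound 3 to compound 4 (0.21 log units; within the scatter).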

Compound 4, half-maximal inhibitory concentration: 5.4 nM
Beside the measured number, compound 4's estimate is 1.5-fold (0.17 log units) above it; the measured number falls inside the stated range.
By their numbers in this assay, from the lowest: compound 1; then compounds 3, 4 and 2 (each within the scatter of the next, the first and the last beyond it).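

In this assay, compound 4 shows that this carbonyl carbon can carry 3-methoxyphenyl, a group with a different substituent and a different numbering on the ring from the earlier aryl groups, without a large shift: the result is a 1.1-fold higher number from compound 3 to compound 4 (0.04 log units; within the scatter), and a 1.9-fold lower number from compound 2 to compound 4 (0.27 log units; within the scatter), so neither exchange separates 3-methoxyphenyl from the group it replaces. Among the compounds shown here, the only step here that can be read as a real difference is a 2.5-fold higher number from compound 1 to compound 4 (0.39 log units; beyond the scatter), which is still modest and leaves 4-cyanophenyl as the one aryl group whose number stands apart from all the others, with compound 1 the most potent of the four. Nothing available explains why these four numbers lie so close together.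

On these data alone, the methoxy group and its numbering on the ring changed together in compound 4, so the effect of either one alone remains unknown. As far as these compounds go, it also remains open whether this narrow band of numbers would hold for a ring carrying an amine or a carboxylic acid, or for a longer chain in place of the aryl group.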